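Swapping an ester for a hydroxyl chain on a shared core

The source may hold more compounds than are shown below. What is called first, only, known or untested is meant among the compounds shown, and "the series" means these compounds.

Measured so far:
- compound 1, `CN1CC[C@H](c2ccc(Cl)cc2)C(C(=O)Oc2ccccc2)C1`: 2180 nM
- compound 2, `CCOC(=O)C[C@H]1CN(C)CC[C@@H]1c1ccc(Cl)cc1`: 101 nM
- compound 3, `CN1CC[C@H](c2ccc(Cl)cc2)[C@@H](CCC(=O)Nc2ccccc2)C1`: 56 nM

Of the compounds shown here, three sharing one core have been tested in an assay on Cortex with Norepinephrine transporter (Rattus norvegicus) as the target; a lower number here means a stronger inhibitor, a higher number a weaker inhibitor. Compound 1 gives 2180 nM, the highest of the three numbers, and thus the weakest inhibitor of the set. Compound 2 gives 101 nM, which places it second highest; its gap to compound 1 lies beyond the usual scatter, whereas its gap to compound 3, which gives 56 nM, lies within it, so compound 2 and compound 3 cannot be told apart on these numbers.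

The next compound, compound 4 `CN1CC[C@H](c2ccc(Cl)cc2)[C@@H](CCCO)C1`, is not yet measured. It differs from compound 2 in one place: 2-hydroxyethyl in place of ethoxycarbonyl on a saturated chain carbon bound to a saturated ring carbon. Going by the values given here, no pair of measured compounds shows this change, so its effect has to be guessed. A modest weakening beyond the scatter seems most likely, though a step within it would not surprise. Compound 4 is therefore expected to give 220 nM (range 60 nM to 800 nM), an estimated step of a 2.2-fold higher number from compound 2 to compound 4 (0.34 log units; beyond the scatter).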

Compound 4, inhibition constant: 564 nM
The estimate for compound 4 lay 2.6-fold (0.41 log units) below the measured number; low and high end bracket the measured number.
By their numbers in this assay, from the lowest: compounds 3 and 2 (each within the scatter of the next); then compound 4; then compound 1.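

In this assay, going by these compounds alone, this position on the shared core proves sensitive to what it carries: 2-hydroxyethyl in place of ethoxycarbonyl gives a 5.6-fold higher number from compound 2 to compound 4 (0.75 log units; beyond the scatter), the first single-place comparison in the set and a clear loss of strength. The change alters several features at once, removing the carbonyl, shortening the group and adding a hydrogen-bond donor, and this one step cannot separate them. No measurement at hand explains the step.

The compounds shown leave open how a carboxylic acid or an amine in place of ethoxycarbonyl would compare with compound 2, and whether a longer chain ending in a hydroxyl would regain the lost strength. Compound 1 and compound 3 carry other chains and offer no single-place comparison with compound 2 to settle this.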